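A few compounds are considered here, and "the series" means these few. Any claim that something is new, unique, unknown or untested is made for them only; others in the source may bear on it.

Measured in a functional assay on MCF7 cells (Homo sapiens) for antiproliferative activity, read by MTT assay, with a stated time of 72 h; on this read-out higher numbers stand for weaker inhibition and lower numbers for stronger inhibition:
- compound 1 `COc1cc(-n2cnc3ccc(-c4ccc(C(C)=O)cc4)cc32)cc(OC)c1OC`: 1540 nM
- compound 2 `COc1ccc(-c2ccc3ncn(-c4cc(OC)c(OC)c(OC)c4)c3c2)cc1F`: 520 nM
- compound 3 `COc1cc(-n2cnc3ccc(-c4cccc(O)c4)cc32)cc(OC)c1OC`: 350 nM

Compound 3 holds the lowest of the three numbers, but only compound 1 lies clearly apart from it, with a 4.4-fold lower number from compound 1 to compound 3 (0.64 log units; beyond the scatter). Compound 2 does not, with a 1.5-fold lower number from compound 2 to compound 3 (0.17 log units; within the scatter).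

Compound 4 `COc1cc(-n2cnc3ccc(-c4cccc(F)c4)cc32)cc(OC)c1OC` is the next analogue. It has fluoro in place of hydroxy on an aromatic carbon, meta to a large group, so 3-hydroxyphenyl becomes 3-fluorophenyl: fluoro in place of hydroxy on an aromatic carbon.

For the measured compounds named here, no measured step isolates this exchange. All three replace a whole substituted phenyl group, so they bear on it only indirectly. The two involving compound 1, a 3.0-fold lower number from compound 1 to compound 2 (0.47 log units; beyond the scatter) and a 4.4-fold lower number from compound 1 to compound 3 (0.64 log units; beyond the scatter), are modest. Both start from the value of compound 1, 1540 nM. The step of a 1.5-fold lower number from compound 2 to compound 3 (0.17 log units; within the scatter) shows that substituents differing more than hydroxy and fluoro can stay within the scatter in this assay. With compound 3 at the low end of the series, any drift is expected toward a higher number, but no change beyond the scatter is expected.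

The expected step is a 1.6-fold higher number from compound 3 to compound 4 (0.20 log units; within the scatter).

For compound 4 the estimate is 550 nM, with an expected range of 200 nM to 1500 nM.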

Compound 4, half-maximal inhibitory concentration: 2350 nM
Beside the measured number, compound 4's estimate is 4.3-fold (0.63 log units) below it; the measured number lies above the stated range.
By their numbers in this assay, from the lowest: compounds 3 and 2 (each within the scatter of the next); then compounds 1 and 4 (each within the scatter of the next).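

In this assay this position proves sensitive to a single-atom exchange: fluoro in place of hydroxy on an aromatic carbon gives a clear loss (a 6.7-fold higher number from compound 3 to compound 4 (0.83 log units; beyond the scatter)), so fluoro does not stand in for hydroxy in 3-hydroxyphenyl. The same loss separates the new compound from the 3-fluoro-4-methoxyphenyl analogue (a 4.5-fold higher number from compound 2 to compound 4 (0.66 log units; beyond the scatter)), while it does not separate it from the 4-acetylphenyl analogue (a 1.5-fold higher number from compound 1 to compound 4 (0.18 log units; within the scatter)), so a fluoro-bearing phenyl group alone does not set the level in this series. Nothing available explains why the hydroxy compound holds the lower number.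

Open, as far as these compounds go, is whether hydroxy is singular at this place, or whether an amine or a carboxylic acid there would hold a similarly low number. Also open, from the compounds shown here alone, is where the unsubstituted phenyl group would fall relative to 3-hydroxyphenyl and 3-fluorophenyl.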